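This account rests on a few compounds, and the source may have more. Where it says the series, first, only, none or still open, it means among the compounds named here.

Of the compounds shown here, two built on a shared core have so far been tested in an ADME assay on Huh-7 cells (Homo sapiens) for cytotoxicity; on this read-out lower numbers stand for stronger inhibition and higher numbers for weaker inhibition. Compound 1 `CN(c1cc2ncc(=O)[nH]c2cc1NC(=S)NC(=O)c1cccc(C(F)(F)F)c1)C1CCCCC1` gives 31500 nM in this assay. Compound 2 `CN(c1cc2ncc(=O)[nH]c2cc1Nc1nc(-c2ccc(F)cc2)cs1)C1CCCCC1` gives 9920 nM in this assay, the lower of the two numbers, and its gap from compound 1 lies beyond the scatter of repeated measurements. Compound 3 `CN(c1cc2ncc(=O)[nH]c2cc1Nc1nc(-c2cccc3ccccc23)cs1)C1CCCCC1` has not yet been measured. It differs from compound 2 in one place: naphthalen-1-yl in place of 4-fluorophenyl on an aromatic carbon, so a group with two six-membered aromatic rings enters where a group with one such ring sat. Going by the values given here, no measured pair shows what a change of this kind does to this read-out, so any expectation rests on compound 2 alone and is uncertain. The step of a 1.4-fold lower number from compound 2 to compound 3 (0.15 log units; within the scatter) is expected to be modest and to point toward a lower number, though a step of no size beyond the scatter would not be surprising. Compound 3 is therefore estimated at 7000 nM in this assay, within a range from 2500 nM to 25000 nM.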

Compound 3, half-maximal inhibitory concentration: 57400 nM
The estimate for compound 3 lay 8.2-fold (0.91 log units) below the measured number, and the stated range ends below it.
By their numbers in this assay, from the lowest: compound 2; then compounds 1 and 3 (each within the scatter of the next).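

Compounds 1 and 2 could not show whether the group on this carbon matters, since they differ in more than one place. Placing naphthalen-1-yl in place of 4-fluorophenyl, on the carbon next to the ring nitrogen of the five-membered aromatic ring, now gives in this assay a 5.8-fold higher number from compound 2 to compound 3 (0.76 log units; beyond the scatter) and so shows that this position does affect the read-out, with the two-ring group on the weaker side of the single one in this pair. Nothing measured here explains this step.

A single pair cannot separate what the second six-membered ring contributes from what the loss of the fluorine contributes, nor say whether the way the two rings are attached plays a part. Plain phenyl, naphthalen-2-yl, or a group of another kind such as methyl or a morpholine on the same carbon would show whether the number keeps rising as the group grows or whether this step is particular to naphthalen-1-yl.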